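The source may report more compounds than this note shows. Statements on the series, on what has been measured and on what is new or still open speak of the compounds shown alone.

In a functional assay on HCT-116 cells (Homo sapiens) for inhibition, read by MTT assay, with a stated time of 72 h (on this read-out lower numbers stand for stronger inhibition and higher numbers for weaker inhibition), compound 2 `CC1=NN(c2ccccc2)C(=O)[C@]12C(=O)C=CC[C@@H]2c1ccc(C)cc1` gives 5800 nM, while compound 1 `CC1=NN(c2ccccc2)C(=O)[C@@]12C(=O)C=CC[C@@H]2c1ccc(C)cc1` gives 5220 nM, and the two cannot be told apart. Among the measured compounds shown here, the only measured step is a 1.1-fold higher number from compound 1 to compound 2 (0.05 log units; within the scatter), and it comes with the fact that compounds 1 and 2 differ only in the configuration as drawn. Compound 3 `CC1=NN(c2ccccc2)C(=O)[C@]12C(=O)C=CC[C@@H]2c1cccc(C)c1` differs from compound 2 in another way, with 3-methylphenyl in place of 4-methylphenyl on a saturated ring carbon. For the measured compounds named here, no measured step moves this methyl group, so the step from compound 1 to compound 2 offers only indirect guidance. The two groups have the same name apart from the methyl position, and nothing measured points in either direction, so no shift beyond the scatter is expected. The expected change is a 1.1-fold lower number from compound 2 to compound 3 (0.02 log units; within the scatter). The estimate for compound 3 is 5500 nM, with an expected range from 2500 nM to 12000 nM.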

Compound 3, half-maximal inhibitory concentration: 5490 nM
For compound 3 the middle estimate is 1.0-fold (0.00 log units) above the measured one; the measured number falls inside the stated range.
By their numbers in this assay, from the lowest: compounds 1, 3 and 2 (each within the scatter of the next).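

In this assay, putting 3-methylphenyl in place of 4-methylphenyl on the saturated ring carbon gives a 1.1-fold lower number from compound 2 to compound 3 (0.02 log units; within the scatter), a step within the scatter. Among the compounds shown here, this is the first measured change to the aryl group at this position, and it shows that the two methyl placements cannot be told apart here. The earlier pair had shown an equally unresolved step of a different kind: the fact that compounds 1 and 2 differ only in the configuration as drawn

The compounds shown leave open whether this position responds to anything other than a methylphenyl group, such as a phenyl bearing a carboxylic acid, an amine or a longer alkyl chain. They also leave open whether the 3-methylphenyl group would give the same result in the stereoisomer represented by compound 1.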